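Trifluoromethoxy in Place of Cyano: an Unmeasured Step

The compounds below may be only part of what the source reports. "The series", "measured", "known", "first", "only" and "open" are said of these compounds alone.

Measured compounds and their values:
Compound 1, `COc1cc(OC)c(/C=C/S(=O)(=O)Cc2ccc(C#N)cc2)c(OC)c1`: 7500 nM
Compound 2, `COc1ccc(CS(=O)(=O)/C=C/c2ccccc2OC)cc1`: 3500 nM
Compound 3, `COc1ccc(CS(=O)(=O)/C=C/c2c(OC)cc(O)cc2OC)cc1`: a limit of the assay, > 20000 nM

All three were tested in a functional assay on DU-145 cells (Homo sapiens) for antiproliferative activity, read by trypan blue exclusion; on this read-out lower numbers stand for stronger inhibition and higher numbers for weaker inhibition. Among the numbers that were reached, compound 1 stands highest: the nearest number, that of compound 2, lies lower by a margin beyond the usual scatter, so compound 2 is the stronger of the two. Compound 3 did not reach a number at all; its result is only a limit (the limit of > 20000 nM in this assay, at which 1 of the 3 values shown sits).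

The next compound, compound 4, is `COc1cc(OC)c(/C=C/S(=O)(=O)Cc2ccc(OC(F)(F)F)cc2)c(OC)c1`. It differs from compound 1 in one place: trifluoromethoxy in place of cyano on an aromatic carbon. Within the data shown here, no measured pair in this set shows what such a swap does, so there is no step to lean on; the only nearby comparison is between compound 1 and compound 2, which differ in several places at once. Without a measured precedent, the expected step in this assay is small, in no firm direction, and likely within the scatter.

The expected step from compound 1 to compound 4 is therefore estimated as a 1.2-fold lower number from compound 1 to compound 4 (0.06 log units; within the scatter). For compound 4 the expected value is 6500 nM, with a range from 2200 nM to 19000 nM.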

Compound 4, half-maximal inhibitory concentration: 4000 nM
Compound 4: the middle estimate sits 1.6-fold (0.21 log units) above what was measured; measured number inside the range.
By their numbers in this assay, from the lowest: compounds 2, 4 and 1 (each within the scatter of the next, the first and the last beyond it). At a limit, above all of these: compound 3.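

In this assay, compound 1 and compound 4 form the only pair shown that differs in one place, and trifluoromethoxy in place of cyano, on an aromatic carbon para to a large group, gives a 1.9-fold lower number from compound 1 to compound 4 (0.27 log units; within the scatter). Among these compounds, this step therefore gives a first reading for this position: trifluoromethoxy carries more heavy atoms than cyano, yet the two compounds cannot be told apart in this read-out, and both groups count the same number of hydrogen-bond acceptors and no net charge. Nothing shown here explains why the two groups read so alike, and the one available piece of supporting information, which concerns a limit of the assay, does not bear on this swap.

Going by these compounds, only these two groups have been compared at this position, so it remains open whether an amine, a carboxylic acid or a longer alkyl chain there would also stay within the scatter of compound 1 or would move the number clearly. Compound 2 and compound 3 differ from compound 4 in more than one place, so they cannot answer that question.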